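Isobutyl to allyl on the ester oxygen of compound 1

The source may report more compounds than this note shows. Statements on the series, on what has been measured and on what is new or still open speak of the compounds shown alone.

Compound 1 `CC(C)COC(=O)NS(=O)(=O)Nc1cccc(-c2cc3ccccc3[nH]2)c1` has so far given only a limit in an assay for inhibition of Polyunsaturated fatty acid lipoxygenase ALOX15 (Oryctolagus cuniculus), read by spectrophotometry; on this read-out higher numbers stand for weaker inhibition and lower numbers for stronger inhibition. In this assay compound 1 gives > 50000 nM, which is a limit of the assay and not a number. Compound 2 `COc1ccc(-c2cc3ccccc3[nH]2)cc1NS(=O)(=O)NC(=O)OCC(C)C` likewise returns only a limit, > 50000 nM. The step that the two limits leave unreadable from compound 1 to compound 2 is therefore unreadable, both values sitting at the same limit (the limit of > 50000 nM in this assay, at which 2 of the 2 values shown sit). The change toward compound 3 `C=CCOC(=O)NS(=O)(=O)Nc1cccc(-c2cc3ccccc3[nH]2)c1` is vinyl in place of isopropyl on a saturated chain carbon bound to an oxygen next to a carbonyl group; cut one bond further out it reads isobutyl to allyl, isobutoxycarbonyl to allyloxycarbonyl. Going by the values given here, no measured step bears on this change, since the only step left no readable size. For compound 3 the expected step that the limit leaves unreadable from compound 1 to compound 3 is none beyond the scatter, with another limit rather than a number the likely outcome. Compound 3 is estimated at 70000 nM, ranging from 20000 nM to 300000 nM.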

Compound 3, half-maximal inhibitory concentration: > 50000 nM
Compound 3 gave a limit, no number; the forecaster's own chance of this, stated with the estimate: 85%; the middle value does not contradict the limit.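

Compound 3 gives > 50000 nM in this assay and this is a limit, not a number. No step between compound 1 and compound 3 can be read, since both sit at the same limit: the limit of > 50000 nM in this assay, at which 3 of the 3 values shown sit.

The compounds shown leave open whether any change to this series reaches a readable inhibition value.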